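This account rests on a few compounds, and the source may have more. Where it says the series, first, only, none or still open, it means among the compounds named here.

In a functional assay on HeLa cells (Homo sapiens) for inhibition, read by MTT assay, with a stated time of 24 h (a lower number here means a stronger inhibitor, a higher number a weaker inhibitor), compound 1 `CCOC(=O)C1=Cc2ccccc2OC1(OCc1cn(CC(=O)Nc2cccc(Cl)c2)nn1)C(F)(F)F` gives 12300 nM, while compound 2 `CCOC(=O)C1=Cc2ccccc2OC1(OCc1cn(CC(=O)Nc2ccc(C)cc2)nn1)C(F)(F)F` gives 67400 nM. For compound 3 `O=C(O)C1=Cc2ccccc2OC1(OCc1cc(-c2ccc([N+](=O)[O-])cc2)no1)C(F)(F)F` the assay reports only a limit, > 150000 nM. Among the two plain numbers, compound 2 has the highest, the weaker inhibitor of the pair; the step of a 5.5-fold higher number from compound 1 to compound 2 (0.74 log units; beyond the scatter) lies beyond the scatter. Compound 4 `CCOC(=O)C1=Cc2ccccc2OC1(OCc1cn(CC(=O)Nc2ccc(I)cc2Cl)nn1)C(F)(F)F` differs from compound 2 in one place: 2-chloro-4-iodophenyl in place of 4-methylphenyl on an amide-type nitrogen. For the measured compounds named here, the only measured step that bears on this, a 5.5-fold higher number from compound 1 to compound 2 (0.74 log units; beyond the scatter), shows a chlorine-bearing phenyl ring giving a modestly lower number than the methyl-bearing one. A drop of similar size is therefore expected, a 4.5-fold lower number from compound 2 to compound 4 (0.65 log units; beyond the scatter), so compound 4 is estimated at 15000 nM, likely between 4000 nM and 60000 nM.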

Compound 4, half-maximal inhibitory concentration: 26100 nM
Compound 4: the middle estimate sits 1.7-fold (0.24 log units) below what was measured; low and high end bracket the measured number.
By their numbers in this assay, from the lowest: compound 1; then compound 4; then compound 2. At a limit, above all of these: compound 3.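

The step of a 2.6-fold lower number from compound 2 to compound 4 (0.41 log units; beyond the scatter) in this assay shows that a ring carrying both chlorine and iodine on the amide-type nitrogen also reads lower than 4-methylphenyl. The step of a 2.1-fold higher number from compound 1 to compound 4 (0.33 log units; beyond the scatter) shows that 2-chloro-4-iodophenyl still falls short of 3-chlorophenyl, so adding halogens to this ring does not simply lower the number. Across compounds 1, 2 and 4, both halogen-bearing rings read lower than the methyl-bearing ring.

As far as these compounds go, how an unsubstituted phenyl or a pyridine ring would read at this position remains open. Nothing given here explains why these rings differ.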